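Glucagon receptor binding: chloro to trifluoromethoxy on the aryl

The source may report more compounds than this note shows. Statements on the series, on what has been measured and on what is new or still open speak of the compounds shown alone.

Measured so far:
compound 1, `O=C(O)CCNC(=O)c1ccc(CN(c2ccc(Cl)cc2)c2nc(-c3ccc(C(F)(F)F)cc3)cs2)cc1`, 76 nM
compound 2, `O=C(O)CCNC(=O)c1ccc(CC(c2ccc(Cl)cc2)c2nc(-c3ccc(OC(F)(F)F)cc3)cs2)cc1`, 153 nM

In an in vitro assay on BHK cells for displacement of a labelled ligand from Glucagon receptor (Homo sapiens), read by scintillation proximity assay (a higher number here means a weaker inhibitor, a lower number a stronger inhibitor), compound 1 gives 76 nM and compound 2 gives 153 nM; the two numbers lie within the scatter of each other, so no order between them can be drawn. Compound 3, `O=C(O)CCNC(=O)c1ccc(CN(c2ccc(OC(F)(F)F)cc2)c2nc(-c3ccc(C(F)(F)F)cc3)cs2)cc1`, has not yet been measured. Compared with compound 1 the change is trifluoromethoxy in place of chloro on an aromatic carbon. Among the compounds with values here, no pair of measured compounds shows this single change, so its size is not known from the data. The step from compound 1 to compound 3 in this assay is expected to be small, a 1.3-fold higher number from compound 1 to compound 3 (0.12 log units; within the scatter), likely not beyond the scatter, with a lean toward a slightly higher number. Compound 3 is estimated at 100 nM, in the range 40 nM to 260 nM.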

Compound 3, half-maximal inhibitory concentration: 92 nM
The estimate for compound 3 lay 1.1-fold (0.04 log units) above the measured number; the measured number falls inside the stated range.
By their numbers in this assay, from the lowest: compounds 1, 3 and 2 (each within the scatter of the next).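

Trifluoromethoxy in place of chloro, on the aromatic carbon para to a large group, can now be read as a single change: in this assay it gives a 1.2-fold higher number from compound 1 to compound 3 (0.08 log units; within the scatter) and stays within the scatter. This position on the shared core therefore accepts either chloro or trifluoromethoxy with no distinction between them in binding. No independent measurement bears on this result.

Still open, on these data alone, is how this position responds to an amine or a carboxylic acid in place of these groups. Also open, as far as these compounds go, is whether the same change reads alike on the core of compound 2.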